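Replacing a secondary amine with a cyclic diamine on the sulfonyl chain

The source may hold more compounds than are shown below. What is called first, only, known or untested is meant among the compounds shown, and "the series" means these compounds.

Three compounds of a shared core have numbers in a physicochemical assay for lipophilicity; a lower number here means a more polar compound, a higher number a more lipophilic compound. Compound 1 `CC(C)NCCS(=O)(=O)c1ccc2nc(NC(=O)NC(=O)c3ccccc3Cl)sc2c1` gives 2.3 and stands second highest of the three. For the measured compounds named here, compound 2 `CN1CCN(CCCS(=O)(=O)c2ccc3nc(NC(=O)NC(=O)c4cccc(-n5cccn5)c4Cl)sc3c2)CC1` gives 1.6, and compound 3 `CN1CCN(CCCS(=O)(=O)c2ccc3nc(NC(=O)NC(=O)c4cc(N5CCCC5)ccc4Cl)sc3c2)CC1` gives 3.1; both carry a different amine on the sulfonyl chain and a different substituted benzoyl group than compound 1, so their values show only that compound 1 lies between them. Going by the values given here, the one step measured within this set, a number 1.50 log units higher from compound 2 to compound 3 (beyond the scatter), changes the benzoyl group alone and leaves the chain amine untouched, so it does not bear on the change now considered.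

Compound 4 `CN1CCCN(CCCS(=O)(=O)c2ccc3nc(NC(=O)NC(=O)c4ccccc4Cl)sc3c2)CC1` keeps the benzoyl group of compound 1 and alters only the chain end: (4-methyl-1,4-diazepan-1-yl)methyl in place of isopropylamino on a saturated chain carbon, two bonds along the chain from a sulfonyl sulfur. Among the compounds with values here, no measured pair isolates this change. Since the entering group is larger and ring-bound but carries two acceptors and no donor, while the leaving group has one of each, the author expects a modest shift toward the polar side, close to the edge of the scatter, and estimates a step of a number 0.40 log units lower from compound 1 to compound 4 (beyond the scatter). For compound 4 in this assay the estimate is therefore 1.9, expected to fall between 1.3 and 2.5.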

Compound 4, distribution coefficient: 1
Compound 4: the middle estimate sits 0.90 log units above what was measured, and the stated range ends above it.
By their numbers in this assay, from the lowest: compound 4; then compound 2; then compound 1; then compound 3.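

For the compounds shown here, with the benzoyl group held fixed, compound 1 and compound 4 form the first pair that isolates the chain end, and this assay gives a number 1.30 log units lower from compound 1 to compound 4 (beyond the scatter). This places the saturated chain among the sites where a single change produces a large step, as the benzoyl group did in a number 1.50 log units higher from compound 2 to compound 3 (beyond the scatter), and the direction is downward even though the entering 3-(4-methyl-1,4-diazepan-1-yl)propyl end has more heavy atoms than the leaving 2-(isopropylamino)ethyl end. Nothing measured here explains the direction or the size of this step.

The change alters the chain end and the ring together, so the compounds shown cannot tell how much of the step belongs to the seven-membered ring and how much to the longer chain; an isopropylamino group on the propyl chain, or a morpholine ring in place of the diazepane, would separate these contributions. Going by these compounds, whether a step of this size would recur with the 2-chloro-5-(pyrrolidin-1-yl)phenyl group on the carbonyl carbon also remains open.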